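Removing One Methoxy Group: From Compound 2 to Compound 4

The source may hold more compounds than are shown below. What is called first, only, known or untested is meant among the compounds shown, and "the series" means these compounds.

Of the compounds shown here, three sharing a core have been tested in a functional assay on MOLT-4 cells (Homo sapiens) for cytotoxicity, read by sulforhodamine B assay, with a stated time of 48 h, tested at 10 uM; a higher number here means a weaker effect of the compound at the concentration tested, a lower number a stronger effect. Compound 2 `COc1cc(-c2cc(/C=C/C(=O)c3ccc(N)cc3)[nH]n2)cc(OC)c1OC` gives -5%. Compound 3 `COc1cc(-c2cc(/C=C/C(=O)c3ccc(F)c(F)c3)[nH]n2)cc(OC)c1OC` gives -4%, and compound 1 `COc1ccc(-c2cc(/C=C/C(=O)c3ccc(N)cc3)[nH]n2)cc1` gives -2%; all three numbers lie within the usual scatter of one another, so none can be said to act more or less strongly than the others. Within the data shown here, the one single-point step known, a number 1 percentage points higher from compound 2 to compound 3 (within the scatter), stays within that scatter. Compound 4 `COc1ccc(-c2cc(/C=C/C(=O)c3ccc(N)cc3)[nH]n2)cc1OC` differs from compound 2 in one place: hydrogen in place of methoxy on an aromatic carbon. Among the measured compounds shown here, no measured step matches this change, and compound 1 and compound 2, which differ in two groups, give numbers within the scatter of each other. In this assay the step of a number 2 percentage points higher from compound 2 to compound 4 (within the scatter) is therefore expected to stay within the scatter. Compound 4 is estimated at -3%, with a range from -13% to 7%.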

Compound 4, a percentage reported as activity, at one concentration (the size of the read-out at that concentration, not a potency): 6%
Compound 4: middle estimate off by 9 percentage points, on the low side; measured number inside the range.
By their numbers in this assay, from the lowest: compounds 2, 3, 1 and 4 (each within the scatter of the next, the first and the last beyond it).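

Among these compounds, replacing this methoxy with hydrogen is the first single change in this assay to go beyond the scatter, giving a number 11 percentage points higher from compound 2 to compound 4 (beyond the scatter), so compound 4 shows a weaker effect than compound 2. The step of methoxy in place of hydrogen on the other aromatic carbon, a number 8 percentage points higher from compound 1 to compound 4 (within the scatter), stays within the scatter and shows no change. No measurement at hand explains the modest step.

Going by these compounds, whether a hydroxyl group or a chlorine atom on this carbon would track compound 2 or compound 4 remains open. So does whether removing this methoxy from compound 3 would give a similar step.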